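Adding an amino link to compound 3

The compounds below may be only part of what the source reports. "The series", "measured", "known", "first", "only" and "open" are said of these compounds alone.

Measured so far in a functional assay on Jurkat cells (Homo sapiens) for antiproliferative activity, read by MTT assay, with a stated time of 72 h; on this read-out lower numbers stand for stronger inhibition and higher numbers for weaker inhibition
compound 1 `COc1cc(C(=O)c2sc3ccccc3c2-c2ccc(SC)cc2)cc(OC)c1OC` gives 1900 nM
compound 2 `COc1ccc(OC)c(-c2c(C(=O)c3cc(OC)c(OC)c(OC)c3)sc3ccccc23)c1` gives > 10000 nM (a limit of the assay)
compound 3 `CCOc1ccc(-c2c(C(=O)c3cc(OC)c(OC)c(OC)c3)sc3ccccc23)cc1` gives 4100 nM

Compound 3 at 4100 nM has the higher of the two actual numbers, and the gap is a 2.2-fold higher number from compound 1 to compound 3 (0.33 log units; beyond the scatter) in this comparison. Compound 2 sits at > 10000 nM which is a limit of the assay and not a number.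

Compound 4 `CCOc1ccc(Nc2c(C(=O)c3cc(OC)c(OC)c(OC)c3)sc3ccccc23)cc1` differs from compound 3 in one place, (4-ethoxyphenyl)amino in place of 4-ethoxyphenyl on an aromatic carbon with (4-ethoxyphenyl)amino in place of 4-ethoxyphenyl. The measured steps that changed the group at this place are an at least 5.2-fold higher number from compound 1 to compound 2 (0.72 log units; beyond the scatter) and an at least 2.4-fold lower number from compound 2 to compound 3 (0.38 log units; beyond the scatter) together with the gap above. All are modest or at least modest, but none adds an amino link, so they guide the size only roughly. In this assay a modest move to a lower number is expected, since compound 1 at 1900 nM shows that this core can reach lower values. The expected change is a 2.7-fold lower number from compound 3 to compound 4 (0.44 log units; beyond the scatter) with considerable uncertainty. Compound 4 is estimated at 1500 nM with 200 nM as the expected lower end and 10000 nM as the upper end.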

Compound 4, half-maximal inhibitory concentration: 300 nM
Beside the measured number, compound 4's estimate is 5.0-fold (0.70 log units) above it; low and high end bracket the measured number.
By their numbers in this assay, from the lowest: compound 4; then compound 1; then compound 3. At a limit, above all of these: compound 2.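

In this assay, adding an amino link to the 4-ethoxyphenyl group on this aromatic carbon gives a 14-fold lower number from compound 3 to compound 4 (1.14 log units; beyond the scatter), so the way the ring is attached matters here, not only the groups the ring carries. The gain also goes past the other compound with a measured number, at a 6.3-fold lower number from compound 1 to compound 4 (0.80 log units; beyond the scatter), although that step swaps methylsulfanyl for ethoxy as well as adding the link. The remaining step is an at least 33-fold lower number from compound 2 to compound 4 (1.52 log units; beyond the scatter), and it rests on a limit, not a number: the limit of > 10000 nM in this assay, at which 1 of the 4 values shown sits.

Going by these compounds, it remains open whether the link must be an amine that keeps its hydrogen, or whether a methylated amine or an ether oxygen would serve as well. On these data alone, it is also open whether the same gain would appear with 2,5-dimethoxyphenyl or 4-(methylsulfanyl)phenyl on the amino link.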